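The source may hold more compounds than are shown below. What is called first, only, known or untested is meant among the compounds shown, and "the series" means these compounds.

Working notes on the cyclopropane-1,1-dicarboxamide series. Compound 1 `CN(C)C(=O)c1cc2cnc(Nc3ccc(NC(=O)C4(C(=O)Nc5ccccc5F)CC4)cc3)nc2n1C1CCCC1` gives 89.6% in a functional assay on NCI-H1299 cells (Homo sapiens) for inhibition, read by CCK-8 assay, with a stated time of 72 h, tested at 10 uM; a lower number here means less inhibition of growth, a higher number more inhibition of growth at the concentration tested. On the three numbers in hand compound 1 sits at one end, with compound 3 `CN(C)C(=O)c1cc2cnc(Nc3ccc(NC(=O)C4(C(=O)Nc5ccc(O)cc5)CC4)cc3)nc2n1C1CCCC1` nearest at 89.7% and compound 2 `CN(C)C(=O)c1cc2cnc(Nc3ccc(NC(=O)C4(C(=O)Nc5ccc(Cl)c(C(F)(F)F)c5)CC4)cc3)nc2n1C1CCCC1` furthest at 90.4%; the step of a number 0.1 percentage points higher from compound 1 to compound 3 (within the scatter) and the step of a number 0.8 percentage points higher from compound 1 to compound 2 (within the scatter) both lie within the scatter, as does a number 0.7 percentage points lower from compound 2 to compound 3 (within the scatter), so the three compounds are not separated by this assay at the concentration tested.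

Compound 4 `CN(C)C(=O)c1cc2cnc(Nc3ccc(NC(=O)C4(C(=O)Nc5ccc(Cl)cc5)CC4)cc3)nc2n1C1CCCC1` has not yet been measured. Against compound 1 the difference is 4-chlorophenyl in place of 2-fluorophenyl on an amide-type nitrogen. The two measured steps that bear on it are those in which the 2-fluorophenyl of compound 1 was exchanged for another aryl on the same amide-type nitrogen, a number 0.8 percentage points higher from compound 1 to compound 2 (within the scatter) and a number 0.1 percentage points higher from compound 1 to compound 3 (within the scatter), and neither moved the number beyond the scatter. The expectation for compound 4 is therefore a step of a number 0.4 percentage points higher from compound 1 to compound 4 (within the scatter), no change beyond the scatter. Compound 4 is estimated at 90%, with a range from 83% to 96%.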

Compound 4, percent growth inhibition at one concentration: 88.6%
Estimate against measurement, compound 4: 1.4 percentage points above; the measured number falls inside the stated range.
By their numbers in this assay, from the lowest: compounds 4, 1, 3 and 2 (each within the scatter of the next).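

In this assay, a chloro group alone on the aryl of this amide-type nitrogen gives a number 1 percentage points lower from compound 1 to compound 4 (within the scatter), so the exchange of 2-fluorophenyl for 4-chlorophenyl leaves the number unresolved from that of compound 1. The two single-group comparisons add what the earlier compounds could not show: chloro in place of hydroxy gives a number 1.1 percentage points lower from compound 3 to compound 4 (within the scatter) and hydrogen in place of trifluoromethyl gives a number 1.8 percentage points lower from compound 2 to compound 4 (within the scatter), so among these four compounds neither the hydroxy nor the trifluoromethyl is required to keep the number in this range. Nothing available explains why these aryl changes leave the number unresolved.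

On these data alone, it remains open whether these aryl groups would separate at other concentrations, since the four compounds are compared here at only one. Also open, as far as these compounds go, is how the number responds to a carboxylic acid or a dimethylamino group on the aryl, or to a cyclohexyl in place of the aryl.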